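The compounds below may be only part of what the source reports. "The series", "measured", "known", "first", "only" and "open" are said of these compounds alone.

For the measured compounds named here, compound 2 `Cc1ccc(OC[C@@H]2C[C@H]3C[C@H]3N2C)cn1` holds the lowest number of the two measured so far in an assay on CHO-K1 cells for displacement of a labelled ligand from Neuronal acetylcholine receptor; alpha4/beta2 (Homo sapiens), read by scintillation counting (on this read-out higher numbers stand for weaker inhibition and lower numbers for stronger inhibition), where compound 2 gives 20 nM. Its nearest neighbour, compound 1 `FC(F)(F)c1ccc(OC[C@@H]2C[C@H]3C[C@H]3N2)cn1`, gives 768 nM in this assay, a gap that lies beyond the scatter. The step to compound 3 `Cc1ccc(OC[C@@H]2C[C@H]3C[C@H]3N2)cn1` is hydrogen in place of methyl on an amine nitrogen in a ring. Going by the values given here, no measured pair isolates this change here, so the direction is open; the step from compound 2 to compound 3 is expected to be a 1.3-fold lower number from compound 2 to compound 3 (0.12 log units; within the scatter), not beyond the scatter. In this assay compound 3 is estimated to give 15 nM, within 4 nM to 60 nM.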

Compound 3, inhibition constant: 26.2 nM
Estimate against measurement, compound 3: 1.7-fold (0.24 log units) below; the measured number falls inside the stated range.
By their numbers in this assay, from the lowest: compounds 2 and 3 (each within the scatter of the next); then compound 1.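

In this assay, the amine nitrogen in a ring accepts hydrogen as well as methyl, with a 1.3-fold higher number from compound 2 to compound 3 (0.12 log units; within the scatter) as the measured step. Methyl in place of trifluoromethyl on an aromatic carbon gives a 29-fold lower number from compound 1 to compound 3 (1.47 log units; beyond the scatter) on the same core, so among these compounds the large step lies at the aromatic carbon, not at the nitrogen. Nothing available here gives a reason for either step. Still open, going by these compounds, is how an ethyl group on that nitrogen would read. Also open, on these data alone, is how chlorine or a methoxy group would read on the aromatic carbon.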